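Working notes: losing the five-membered non-aromatic ring

The compounds below may be only part of what the source reports. "The series", "measured", "known", "first", "only" and "open" are said of these compounds alone.

In a functional assay on KB cells (Homo sapiens) for inhibition, read by MTT assay, with a stated time of 24 h, tested at 100 ug/mL (on this read-out lower numbers stand for less inhibition of growth and higher numbers for more inhibition of growth at the one concentration tested), compound 1 `O=C(CCCCC1CCSS1)Nc1ccc(Cl)cn1` gives 74.5%, the higher of the two numbers available, while compound 2 `O=C(CCCCC1CCSS1)Nc1ccc(Br)cn1` gives 42.3%. Compound 3 `O=C(CCCCC(S)CCS)Nc1ccccc1Cl` is recorded only as "not active" (no number reported), without a number.

Compound 4 `O=C(CCCCC(S)CCS)Nc1ccc(Cl)cn1` departs from compound 1 by a single change: a group of 5 heavy atoms (3 carbon, 2 sulfur; no ring) in place of a group of 5 heavy atoms (3 carbon, 2 sulfur; one five-membered non-aromatic ring with 2 hetero atoms), on a saturated chain carbon, four bonds along the chain from a carbonyl carbon. The 1,3-disulfanylpropyl group therefore replaces the ring. Among the measured compounds shown here, the only measured single-site step, a number 32.2 percentage points lower from compound 1 to compound 2 (beyond the scatter), is a bromo for chloro exchange on an aromatic carbon, so it gives no direct measure for this change. For the measured compounds named here, it shows only that one exchange can move the read-out substantially. Compound 3 also carries the 1,3-disulfanylpropyl group and stands at "not active" (no number reported), although it differs from compound 4 elsewhere as well. A fall in this assay is therefore expected, with wide uncertainty.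

The expected change is a number 34.5 percentage points lower from compound 1 to compound 4 (beyond the scatter). The estimate for compound 4 is 40%, within an expected range of 10% to 65%.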

Compound 4, percent growth inhibition at one concentration: 76.6%
Compound 4: the middle estimate sits 36.6 percentage points below what was measured; the measured number lies above the stated range.
By their numbers in this assay, from the lowest: compound 2; then compounds 1 and 4 (each within the scatter of the next).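

In this assay the 1,3-disulfanylpropyl group in place of the five-membered non-aromatic ring gives a number 2.1 percentage points higher from compound 1 to compound 4 (within the scatter) and so does not separate the two groups at this position, on a saturated chain carbon, four bonds along the chain from a carbonyl carbon. The closed ring is therefore not required for this level of growth inhibition on the core of compound 1, even though the entering group carries 2 hydrogen-bond donors and the leaving group has none. No supporting measurement bears on why the two groups read alike.

Still open, as far as these compounds go, is whether the same exchange holds on the bromo compound 2, where the read-out starts from a different level. A carboxylic acid or a longer chain at this position remains untested in the compounds shown, and a single concentration says nothing about how the compounds compare across a range of concentrations.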